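The compounds below may be only part of what the source reports. "The series", "measured", "known", "first", "only" and "open" are said of these compounds alone.

Of the compounds shown here, three with a shared core have been measured in a functional assay with Alpha-1B adrenergic receptor (Homo sapiens) as the target, read by calcium flux; on this read-out higher numbers stand for larger maximal responses and lower numbers for smaller maximal responses. Compound 1 `Cn1cccc1-c1ccccc1NCC1=NCCN1` gives 0%, and compound 2 `Cn1cc(-c2ccccc2NCC2=NCCN2)cn1` gives 0%; the step of no change at the digits printed from compound 1 to compound 2 (within the scatter). Compound 3 `c1ccc(-c2cn[nH]c2)c(NCC2=NCCN2)c1` gives 72%, the highest of the three numbers, with a number 72 percentage points higher from compound 1 to compound 3 (beyond the scatter) and a number 72 percentage points higher from compound 2 to compound 3 (beyond the scatter), both beyond the scatter.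

Compound 4 `CCn1cc(-c2ccccc2NCC2=NCCN2)cn1` differs from compound 3 in one place: ethyl in place of hydrogen on an aromatic nitrogen. The step that bears on it most directly is a number 72 percentage points higher from compound 2 to compound 3 (beyond the scatter), where removing a methyl from that aromatic nitrogen gave the whole response; compound 4 puts an ethyl on the same nitrogen, so a return to a small response is expected. The step of no change at the digits printed from compound 1 to compound 2 (within the scatter) shows that the two methylated compounds sit together at the bottom. A large downward step is therefore expected in this assay: a number 67 percentage points lower from compound 3 to compound 4 (beyond the scatter). Compound 4 is estimated at 5%, within a range from 0% to 30%.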

Compound 4, largest response reached (reported as maximal response), in percent of the reference or control that the assay uses: 0%
Compound 4: the middle estimate sits 5 percentage points above what was measured; measured number inside the range.
By their numbers in this assay, from the lowest: compounds 1, 2 and 4 (each within the scatter of the next); then compound 3.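

In this assay there is a number 72 percentage points lower from compound 3 to compound 4 (beyond the scatter) and no change at the digits printed from compound 2 to compound 4 (within the scatter) for the ethyl group, so a methyl group is not alone in removing the response at this aromatic nitrogen. Among compounds 2, 3 and 4, which differ only in what this nitrogen carries, compound 3, with hydrogen there, is the only one that gives a response, and going from methyl to ethyl adds nothing that this read-out can detect. Nothing shown here explains why the hydrogen matters so much.

Going by these compounds, it remains open whether every group on this nitrogen has the same effect, for instance a longer chain such as propyl, a 2-hydroxyethyl chain or an acetyl group. A small group such as hydroxyl or an amine on that nitrogen could also test how narrow the requirement is.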